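Chloro to carboxy on the aryl tetrazole end

A few compounds are considered here, and "the series" means these few. Any claim that something is new, unique, unknown or untested is made for them only; others in the source may bear on it.

Measured so far:
- Compound 1, `CCCCCCCCc1ccc(OC(C)C(=O)Cn2nnc(-c3ccc(Cl)cc3)n2)cc1`: in an assay on microsomes from brain for inhibition of Fatty-acid amide hydrolase 1 (Rattus norvegicus), read by fluorescence and HPLC, with a stated time of 60 min (on this read-out lower numbers stand for stronger inhibition and higher numbers for weaker inhibition), compound 1 gives 35 nM.
- Compound 2, `CC(Oc1ccc(Oc2ccc(C(F)(F)F)cc2)cc1)C(=O)Cn1nnc(-c2ccc(Cl)cc2)n1`: in this assay compound 2 gives 300 nM.

Among the measured compounds shown here, compound 2 holds the highest number of the two measured; its nearest neighbour is compound 1, and the only measured step, an 8.6-fold higher number from compound 1 to compound 2 (0.93 log units; beyond the scatter), concerns the other end of the shared core.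

Compound 3, `CC(Oc1ccc(Oc2ccc(C(F)(F)F)cc2)cc1)C(=O)Cn1nnc(-c2ccc(C(=O)O)cc2)n1`, differs from compound 2 in one place: carboxy in place of chloro on an aromatic carbon. For the measured compounds named here, no measured step touches this position; the single step recorded, an 8.6-fold higher number from compound 1 to compound 2 (0.93 log units; beyond the scatter), bears on a distant part of the molecule and says nothing about a carboxy group at the aryl tetrazole end. The expectation for compound 3 rests on the size of the change alone: a chloro group gives way to a carboxy group, and the number in this assay is expected to rise, with wide uncertainty. The step for compound 3 is estimated as a 6.7-fold higher number from compound 2 to compound 3 (0.82 log units; beyond the scatter). For compound 3 in this assay the estimate is 2000 nM, with a range from 400 nM to 10000 nM.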

Compound 3, half-maximal inhibitory concentration: 160 nM
Compound 3: the middle estimate sits 13-fold (1.10 log units) above what was measured; measured number outside the range, below it.
By their numbers in this assay, from the lowest: compound 1; then compounds 3 and 2 (each within the scatter of the next).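

In this assay the exchange of 4-chlorophenyl for 4-carboxyphenyl leaves compound 2 and compound 3 within the scatter of each other (a 1.9-fold lower number from compound 2 to compound 3 (0.27 log units; within the scatter)). Among the compounds shown here, this is the first reading at this position, and on the 4-(trifluoromethyl)phenoxy background it does not separate chloro from carboxy, even though carboxy brings more heavy atoms, a double bond outside the aromatic rings, and a hydrogen-bond donor and acceptor. For the compounds shown here, the only earlier step, at the other end of the molecule, lies beyond the scatter (an 8.6-fold higher number from compound 1 to compound 2 (0.93 log units; beyond the scatter)), so in these three compounds only that end shows a change that can be read, and no measurement at hand explains why the exchange on the aromatic ring leaves the number within the scatter.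

Open at this position are an amine, a methyl ester and a primary amide, along with a carboxymethyl group, which would set the acid one carbon further from the ring. Also open, as far as these compounds go, is whether carboxy in place of chloro reads the same with the octyl chain of compound 1 at the other end.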